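This account rests on a few compounds, and the source may have more. Where it says the series, first, only, none or still open, it means among the compounds named here.

Compounds measured so far:

compound 1, `CC1=NC(C)=C(C(=O)O)C(c2ccccc2)/C1=C(\O)OC/C=C/c1ccccc1`, 9 nM in a functional assay on thoracic aorta for inhibition of Voltage-gated L-type calcium channel (Rattus norvegicus); a lower number here means a stronger inhibitor, a higher number a weaker inhibitor
compound 2, `CC1=NC(C)=C(C(=O)O)C(c2cccc(C)c2)/C1=C(\O)OC/C=C/c1ccccc1`, 76 nM in this assay
compound 3, `CC1=NC(C)=C(C(=O)O)C(c2cccc(Cl)c2)/C1=C(\O)OC/C=C/c1ccccc1`, 20 nM in this assay

Compound 3 holds the second highest of these three numbers. It lies closest to compound 1, as a 2.2-fold higher number from compound 1 to compound 3 (0.35 log units; beyond the scatter) shows, and furthest from compound 2, with a 3.8-fold lower number from compound 2 to compound 3 (0.58 log units; beyond the scatter) separating them. Compound 4, `CC1=NC(C)=C(C(=O)O)C(c2cccc(Cl)c2)/C1=C(\O)OC/C=C/c1ccc(Cl)cc1`, is compound 3 with one further change: chloro in place of hydrogen on an aromatic carbon, so that the 3-phenylprop-2-en-1-yl chain becomes 3-(4-chlorophenyl)prop-2-en-1-yl.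

For the measured compounds named here, no measured step touches this chain; the three measured steps all alter the other six-membered ring, the one attached to the shared core. The closest guide is a 2.2-fold higher number from compound 1 to compound 3 (0.35 log units; beyond the scatter), where the same chloro group entering the other ring gave a modest rise, and an 8.4-fold higher number from compound 1 to compound 2 (0.93 log units; beyond the scatter) shows that a methyl on that ring raised the number further. Those steps speak for the other ring, not for this chain, so they only hint that a single small group added to an aromatic carbon changes the number modestly here. The expectation for compound 4 is therefore a modest shift, a 1.5-fold higher number from compound 3 to compound 4 (0.18 log units; within the scatter), in this assay.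

Compound 4 is estimated at 30 nM, within a range of 8 nM to 110 nM.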

Compound 4, half-maximal inhibitory concentration: 5.8 nM
Compound 4: the middle estimate sits 5.2-fold (0.71 log units) above what was measured; measured number outside the range, below it.
By their numbers in this assay, from the lowest: compounds 4 and 1 (each within the scatter of the next); then compound 3; then compound 2.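

In this assay, chloro in place of hydrogen on the aromatic ring of the 3-phenylprop-2-en-1-yl chain, para to a large group, gives a 3.4-fold lower number from compound 3 to compound 4 (0.54 log units; beyond the scatter). This is the first step shown that alters this chain, and it shows that the chain's ring is not a silent part of the molecule: a single added chlorine moves the number downward, beyond the scatter. The same kind of swap on the other six-membered ring went the opposite way, with a 2.2-fold higher number from compound 1 to compound 3 (0.35 log units; beyond the scatter), so among these compounds the direction of the change depends on which ring carries the chloro, and no measurement shown accounts for this difference.

The compounds shown leave open whether a methyl, a methoxy or a fluoro in place of this chloro would also lower the number, and whether an amine or a carboxylic acid on this ring would be tolerated at all. They also leave open whether the 3-(4-chlorophenyl)prop-2-en-1-yl chain would give a similar step on compound 1, whose other ring carries no chloro.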